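The compounds below may be only part of what the source reports. "The series", "measured", "known", "first", "only" and "open" are said of these compounds alone.

Compound 1 `O=C1C(=Cc2ccc(F)cc2)C(=O)N(c2ccc(Cl)cc2)N1c1ccc(Cl)cc1`: 23300 nM
Compound 2 `O=C1C(=Cc2ccc(Br)cc2)C(=O)N(c2ccc(Cl)cc2)N1c1ccc(Cl)cc1`: 16600 nM
Compound 3 `COc1cc(C=C2C(=O)N(c3ccc(Cl)cc3)N(c3ccc(Cl)cc3)C2=O)cc(OC)c1OC`: 29500 nM

These three results come from a functional assay on SMMC-7721 cells (Homo sapiens) for cytotoxicity, read by MTT assay, with a stated time of 72 h; a lower number here means a stronger inhibitor, a higher number a weaker inhibitor. Among the compounds with values here, compound 1 gives 23300 nM there, and the values of compound 2 and compound 3 both lie within the scatter of it, so no measured compound stands apart from compound 1.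

The next compound is compound 4 `O=C1C(=Cc2cccc(Cl)c2)C(=O)N(c2ccc(Cl)cc2)N1c1ccc(Cl)cc1`, still to be measured. It differs from compound 1 as follows: 3-chlorophenyl in place of 4-fluorophenyl on a double-bonded chain carbon bound to a double-bonded ring carbon. That is, 3-chlorophenyl stands in place of 4-fluorophenyl on a double-bonded chain carbon bound to a double-bonded ring carbon.

Within the data shown here, one measured step bears on this change: a 1.4-fold lower number from compound 1 to compound 2 (0.15 log units; within the scatter), bromo in place of fluoro on an aromatic carbon. It is small and lies within the scatter. Among the measured compounds shown here, no measured compound carries the 3-chlorophenyl group, so the change itself remains untested, and only a step within the scatter is expected in this assay, with no firm direction.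

The expected step is a 1.1-fold lower number from compound 1 to compound 4 (0.05 log units; within the scatter).

For compound 4 the estimated value is 21000 nM, with an expected range of 10000 nM to 42000 nM.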

Compound 4, half-maximal inhibitory concentration: 20200 nM
Compound 4: the middle estimate sits 1.0-fold (0.02 log units) above what was measured; the measured number falls inside the stated range.
By their numbers in this assay, from the lowest: compounds 2, 4, 1 and 3 (each within the scatter of the next).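

In this assay, 3-chlorophenyl in place of 4-fluorophenyl on a double-bonded chain carbon bound to a double-bonded ring carbon gives a 1.2-fold lower number from compound 1 to compound 4 (0.06 log units; within the scatter), and the same group in place of 4-bromophenyl gives a 1.2-fold higher number from compound 2 to compound 4 (0.09 log units; within the scatter). Until now this position had been read for bromo in place of fluoro on the aromatic carbon, and compound 4 adds that a change in both the halogen and the group's name from 4- to 3-substituted phenyl also stays within the scatter, in both comparisons. Nothing measured here accounts for how close these numbers lie.

From the compounds shown here alone, whether an amine or a carboxylic acid on this phenyl ring would move the number beyond the scatter stays open. So does the effect of any change to the shared core itself.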